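Cytotoxicity of Diaryl Chain Analogues: Replacing the Hydroxymethyl

A few compounds are considered here, and "the series" means these few. Any claim that something is new, unique, unknown or untested is made for them only; others in the source may bear on it.

The compounds share a saturated chain carbon bound to two aromatic carbons and were tested in a functional assay on HeLa cells (Homo sapiens) for cytotoxicity, read by WST assay, with a stated time of 48 h; on this read-out higher numbers stand for weaker inhibition and lower numbers for stronger inhibition. Compound 1 `COc1ccc(C(c2ccc(OC)c(OC)c2)[C@@H](C)[C@H](C)CO)cc1OC` gives only a limit in this assay, > 100000 nM. Compound 3 `COc1ccc(C(c2ccc(OC)c(OC)c2)[C@@H](C)[C@@H](C)CO)cc1OC` likewise gives a limit, > 100000 nM. These two differ only in configuration, and the step that the two limits leave unreadable from compound 1 to compound 3 cannot be read: the fact that compounds 1 and 3 differ only in the configuration as drawn together with the limit of > 100000 nM in this assay, at which 3 of the 3 values shown sit, leaves its size open. Compound 2 `COc1cc(C(c2ccc(O)c(OC)c2)[C@@H](CO)C(C)C)ccc1O` also reaches only a limit, > 100000 nM. On the numbers shown, compound 2 thus stands at the same limit as the other two, and nothing separates them.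

Compound 4 `COc1cc(C(c2ccc(O)c(OC)c2)[C@H](CC(C)C)C(C)C)ccc1O` has not been measured. Compared with compound 2 it carries 1-isopropyl-3-methylbutyl in place of 1-(hydroxymethyl)-2-methylpropyl on a saturated chain carbon bound to two aromatic carbons. Going by the values given here, no measured step touches this change; the only measured step, the configurational one between compounds 1 and 3, is unreadable. Every value in hand sits at the limit (the limit of > 100000 nM in this assay, at which 3 of the 3 values shown sit). The step from compound 2 to compound 4 is therefore expected to be a number no higher from compound 2 to compound 4 (the limit leaves the size open), no readable change. Compound 4 is expected to give 100000 nM in this assay, with a range from 30000 nM to 300000 nM, most probably again reported only as a limit.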

Compound 4, half-maximal inhibitory concentration: 8200 nM
For compound 4 the middle estimate is 12-fold (1.09 log units) above the measured one; measured number outside the range, below it.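

In this assay, going by these compounds alone, there is an at least 12-fold lower number from compound 2 to compound 4 (1.08 log units; beyond the scatter) and with it the first readable number. Within the data shown here, the group on a saturated chain carbon bound to two aromatic carbons therefore matters in this assay: with the rest of compound 2 unchanged, exchanging 1-(hydroxymethyl)-2-methylpropyl for 1-isopropyl-3-methylbutyl moves the compound off the limit, something the earlier compounds, all sitting at a limit, could not show. Nothing in the evidence at hand accounts for the size of this step.

The exchange removes the hydroxymethyl and enlarges the carbon chain in a single change, so the compounds shown do not separate these two parts, and the step between compound 1 and compound 3 remains unreadable, which leaves the role of configuration open as well. As far as these compounds go, whether an amine, a carboxylic acid or a longer chain at this place would keep, lower or raise the number also remains open.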